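The source may report more compounds than this note shows. Statements on the series, on what has been measured and on what is new or still open speak of the compounds shown alone.

Compound 1 `Cc1ccc(C(=O)NC(N)=O)cc1NC(=O)CBr`: 4280 nM
Compound 2 `Cc1ccc(C(=O)NC(N)=O)cc1NC(=O)CCl`: 3360 nM

In a functional assay on CCRF-CEM cells (Homo sapiens) for antiproliferative activity, read by trypan blue exclusion, with a stated time of 72 h (on this read-out higher numbers stand for weaker inhibition and lower numbers for stronger inhibition), compound 2 gives 3360 nM, within the scatter of compound 1 at 4280 nM. Compound 3 `NC(=O)NC(=O)c1ccc(O)c(NC(=O)CCl)c1` carries hydroxy in place of methyl on an aromatic carbon. For the measured compounds named here, the only measured step, a 1.3-fold lower number from compound 1 to compound 2 (0.11 log units; within the scatter), concerns chloro in place of bromo on a saturated chain carbon, so it does not bear directly on this change. Going by the values given here, no measured step shows what this exchange does, so no direction can be argued and a wide range is warranted. The expected change is a 1.2-fold higher number from compound 2 to compound 3 (0.08 log units; within the scatter), not beyond the scatter. For compound 3 the estimated value is 4000 nM, with an expected range from 1000 nM to 15000 nM.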

Compound 3, half-maximal inhibitory concentration: > 20000 nM
Compound 3 ended at the assay's limit; the forecaster's own chance of this, stated with the estimate: 10%; middle value at least 5.0-fold (0.69 log units) from the limit.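

In this assay, the position ortho to the ((chloromethyl)carbonyl)amino group and para to the carbamoylcarbamoyl group responds to its substituent, as hydroxy in place of methyl gives an at least 5.9-fold higher number from compound 2 to compound 3 (0.77 log units; beyond the scatter). For compound 3 the read-out is a limit and not a number: the limit of > 20000 nM in this assay, at which 1 of the 3 values shown sits. The halogen exchange between compound 1 and compound 2 stayed within the scatter, so this is the first change shown to move the number beyond it, though its full size remains unknown.

The compounds shown leave open how an amine, a methoxy group or a fluoro group would read at this position. They also leave open whether hydroxy has the same effect when bromo replaces chloro on the chain.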